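Carboxypyridinyl for pyridinyl on the ketone-bearing core

The source may hold more compounds than are shown below. What is called first, only, known or untested is meant among the compounds shown, and "the series" means these compounds.

The measured compounds are:
compound 1, `O=C(CCc1ccc(-c2ccccc2)cc1)c1ncc(-c2ccncc2)o1`, 2.3 nM;
compound 2, `CN(C)C(=O)c1cnc(C(=O)CCc2ccc(COc3ccccc3)cc2)o1`, 6.7 nM;
compound 3, `O=C(O)c1cccc(-c2cnc(C(=O)CCc3ccc(-c4ccc(CN5CCCCC5)cc4)cc3)o2)n1`, 44 nM.

In an assay for inhibition of Fatty-acid amide hydrolase 1 (Rattus norvegicus) (a lower number here means a stronger inhibitor, a higher number a weaker inhibitor), compound 1 gives the lowest of the three numbers. Compound 2 sits nearest to it, and the gap between compound 1 and compound 2 lies beyond the usual scatter; compound 3 sits furthest, its gap to compound 1 also beyond the scatter. Compound 1 is thus the strongest inhibitor of the three.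

Compound 4, `O=C(O)c1ccc(-c2cnc(C(=O)CCc3ccc(-c4ccccc4)cc3)o2)nc1`, has not been measured in this assay. It differs from compound 1 in one place: 5-carboxypyridin-2-yl in place of pyridin-4-yl on an aromatic carbon. Within the data shown here, compound 3, which carries an acid on a pyridin-2-yl at the same position of the core together with a different tail, gives the highest number of the three, but no single step between measured compounds isolates that change.

An increase in the number is expected, of moderate size, beyond the scatter: the step from compound 1 to compound 4 is estimated at a 4.3-fold higher number from compound 1 to compound 4 (0.64 log units; beyond the scatter). Compound 4 is expected to give about 10 nM, within a range from 2.5 nM to 45 nM.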

Compound 4, inhibition constant: 14 nM
Compound 4: middle estimate off by 1.4-fold (0.15 log units), on the low side, within the range that was stated.
By their numbers in this assay, from the lowest: compound 1; then compound 2; then compound 4; then compound 3.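

Among these compounds, compound 4 gives the first single-place reading at this position: in this assay, 5-carboxypyridin-2-yl in place of pyridin-4-yl on the aromatic carbon next to the ring oxygen brings a 6.1-fold higher number from compound 1 to compound 4 (0.78 log units; beyond the scatter). The position therefore accepts a larger group carrying a carboxylic acid at a modest cost, and compound 4 still gives 14 nM. Nothing measured here explains the size of this step.

The change alters two things at once, the way the pyridine ring is attached and the presence of the carboxylic acid, so the compounds shown do not tell which of the two accounts for the step. A plain pyridin-2-yl, or a methyl ester or primary amide in place of the acid on the same ring, would separate the two.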